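A few compounds are considered here, and "the series" means these few. Any claim that something is new, unique, unknown or untested is made for them only; others in the source may bear on it.

Compounds measured so far:
Compound 1, `CCCCCCCCOC1CC(=O)Nc2c1c(C)nn2-c1ncnc2nc[nH]c12`: 8 nM
Compound 2, `Cc1nn(-c2ncnc3nc[nH]c23)c2c1C(C(=O)NCc1ccccc1)CC(=O)N2`: 5 nM
Compound 3, `Cc1noc(C)c1COC1CC(=O)Nc2c1c(C)nn2-c1ncnc2nc[nH]c12`: 5 nM

All three share one core and differ only in the group carried on a saturated ring carbon of the six-membered non-aromatic ring. In a functional assay on HEK293 cells for agonist activity at G-protein coupled receptor 39 (Homo sapiens), read by scintillation proximity assay and inositol phosphate accumulation, with a stated time of 75 min, in the presence of a further agent that is not named here (on this read-out lower numbers stand for an effect already at smaller amounts and higher numbers for an effect only at larger amounts of compound), compound 3 stands level with compound 2; the number for compound 1 differs by a 1.6-fold lower number from compound 1 to compound 3 (0.20 log units; within the scatter). For the measured compounds named here, every step so far sits inside the ordinary scatter: a 1.6-fold lower number from compound 1 to compound 2 (0.20 log units; within the scatter) and no change at the digits printed from compound 2 to compound 3 (within the scatter).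

Compound 4, `Cc1nn(-c2ncnc3nc[nH]c23)c2c1C(C(=O)N(C)c1ccccc1)CC(=O)N2`, has not yet been tested. It changes the same position again: methyl(phenyl)carbamoyl in place of (3,5-dimethyl-1,2-oxazol-4-yl)methoxy on a saturated ring carbon. Two earlier steps bear on this. Exchanging an ether for a carbamoyl group, and back again, moved nothing beyond the scatter, as seen in a 1.6-fold lower number from compound 1 to compound 2 (0.20 log units; within the scatter) and no change at the digits printed from compound 2 to compound 3 (within the scatter). Compound 2 already carries a carbamoyl group bearing a phenyl ring, and its value lies beside that of compound 3. Going by the values given here, no step in this assay beyond the scatter is therefore expected for compound 4 in either direction. The expected change, then, is a 1.2-fold higher number from compound 3 to compound 4 (0.08 log units; within the scatter). Compound 4 is estimated to give 6 nM, within a range from 2 nM to 20 nM.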

Compound 4, half-maximal effective concentration: 32 nM
Estimate against measurement, compound 4: 5.3-fold (0.73 log units) below; measured number above the stated range.
By their numbers in this assay, from the lowest: compounds 2, 3 and 1 (each within the scatter of the next); then compound 4.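

For the compounds shown here, putting methyl(phenyl)amino in place of benzylamino on the carbonyl carbon gives a 6.4-fold higher number from compound 2 to compound 4 (0.81 log units; beyond the scatter) in this assay and is the first step at this position beyond the scatter, so carrying a carbamoyl group with a phenyl ring does not by itself keep the number low. Compound 4 also stands apart from the two ether compounds, with a 6.4-fold higher number from compound 3 to compound 4 (0.81 log units; beyond the scatter) and a 4.0-fold higher number from compound 1 to compound 4 (0.60 log units; beyond the scatter) on the same read-out, so the position does respond to the group placed on it. Nothing here gives a measured reason for these steps.

Compound 4 gains a methyl on the amide nitrogen and also has its phenyl ring bound directly to that nitrogen, and the compounds shown do not separate these two changes. Phenylcarbamoyl and methyl(benzyl)carbamoyl, each carrying only one of them, remain open.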